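Hydrogen for ethoxy on the bicyclic part of compound 1

The compounds below may be only part of what the source reports. "The series", "measured", "known", "first", "only" and "open" are said of these compounds alone.

Three compounds carry measurements in a functional assay on CCRF-CEM cells (Homo sapiens) for antiproliferative activity, read by fluorescence and resazurin assay, with a stated time of 48 h; a lower number here means a stronger inhibitor, a higher number a weaker inhibitor. Compound 1 `CCOc1ccc2nc(Cl)c(/C=N/NC(=O)c3cc4cc(Br)ccc4oc3=O)cc2c1` gives 12900 nM, the lowest of the three numbers. Compound 2 `CCOc1ccc(NC(=O)c2cc3cc(Br)ccc3oc2=O)cc1` gives 21800 nM, which stands within the scatter of compound 1. Compound 3 `Cc1noc(NS(=O)(=O)c2ccc(NC(=O)c3cc4ccccc4oc3=O)cc2)c1C` gives 26600 nM, which lies beyond the scatter of compound 1. Going by the values given here, no pair of these three differs in a single place, so no measured step can be read from them, and compound 1 cannot be called the strongest of the set on these numbers.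

Compound 4 `O=C(N/N=C/c1cc2ccccc2nc1Cl)c1cc2cc(Br)ccc2oc1=O` is not yet measured in this assay . It differs from compound 1 in one place: hydrogen in place of ethoxy on an aromatic carbon.

Among the compounds with values here, no step of this kind is available among the measured compounds. The shared core is kept, and the change removes a small group and puts hydrogen in its place on the outer ring. With nothing in the measured set to point either way, the step from compound 1 to compound 4 is expected to be small, in either direction, and most likely within the scatter; the estimated step is a 1.2-fold higher number from compound 1 to compound 4 (0.07 log units; within the scatter).

Compound 4 is therefore expected to give about 15000 nM in this assay , with a likely range from 6000 nM to 40000 nM.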

Compound 4, half-maximal inhibitory concentration: 7450 nM
Beside the measured number, compound 4's estimate is 2.0-fold (0.30 log units) above it; measured number inside the range.
By their numbers in this assay, from the lowest: compounds 4, 1, 2 and 3 (each within the scatter of the next, the first and the last beyond it).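

In this assay, going by these compounds alone, hydrogen in place of ethoxy on the aromatic carbon gives a 1.7-fold lower number from compound 1 to compound 4 (0.24 log units; within the scatter), the first step that can be read at this position, and it shows that the ethoxy group can be removed from the shared core with no difference beyond the scatter, so compound 1 and compound 4 cannot be told apart on these numbers and ethoxy is not required for activity at this level. Within the data shown here, compound 2 and compound 3 each differ from compound 4 in more than one place, so no step to either of them can be read, and this single pair remains the only evidence about this position. Nothing measured here accounts for the size of the step, and no cause can be assigned to it.

Still open, from the compounds shown here alone, is whether any other group on this aromatic carbon, such as an amine, a carboxylic acid, a fluorine atom or a longer alkoxy chain, would move the number beyond the scatter. Also open, going by these compounds, is whether ethoxy and hydrogen would stay as close as they do here if the shared core were changed elsewhere.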